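The compounds below may be only part of what the source reports. "The series", "measured", "known", "first", "only" and "open" are said of these compounds alone.

In a functional assay on MCF7 cells (Homo sapiens) for inhibition, read by MTT assay, with a stated time of 72 h (a higher number here means a weaker inhibitor, a lower number a stronger inhibitor), compound 1 (`Cc1cc(Nc2ccn(Cc3cccc4ccccc34)n2)n2nc(SCc3ccc(Br)cc3)nc2n1`) gives 4310 nM while compound 2 (`Cc1cc(Nc2ccn(Cc3ccc(F)cc3)n2)n2nc(SCc3ccc(Br)cc3)nc2n1`) gives 4280 nM and compound 3 (`Cc1cc(Nc2ccn(Cc3csc4ccc(Cl)cc34)n2)n2nc(SCc3ccc(Br)cc3)nc2n1`) gives 2570 nM on the same read-out. Compound 3 is not separated from either of the others: a 1.7-fold lower number from compound 1 to compound 3 (0.22 log units; within the scatter) and a 1.7-fold lower number from compound 2 to compound 3 (0.22 log units; within the scatter) both stay within the scatter.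

Compound 4 (`Cc1ccc(Cn2ccc(Nc3cc(C)nc4nc(SCc5ccc(Br)cc5)nn34)n2)cc1`) differs from compound 3 in one place, (4-methylphenyl in place of 5-chloro-1-benzothiophen-3-yl on a saturated chain carbon bound to an aromatic nitrogen), with 4-methylphenyl in place of 5-chloro-1-benzothiophen-3-yl on a saturated chain carbon bound to an aromatic nitrogen.

All three measured steps changed this same group. Within the data shown here, the nearest precedent is compound 2, which also has one six-membered aromatic ring of carbon only here, and its step to the benzothiophene is a 1.7-fold lower number from compound 2 to compound 3 (0.22 log units; within the scatter) in size. The step of a 1.0-fold lower number from compound 1 to compound 2 (0.00 log units; within the scatter) likewise shows no separation. No step beyond the scatter is therefore expected in this assay at this place. The expected step is a 1.5-fold higher number from compound 3 to compound 4 (0.17 log units; within the scatter) and no more than that. Compound 4 is estimated at 3800 nM with an expected range from 2000 nM to 7000 nM in this series.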

Compound 4, half-maximal inhibitory concentration: 11300 nM
Compound 4: middle estimate off by 3.0-fold (0.47 log units), on the low side; the whole stated range lies below it.
By their numbers in this assay, from the lowest: compounds 3, 2 and 1 (each within the scatter of the next); then compound 4.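

The position on a saturated chain carbon bound to an aromatic nitrogen does respond in this assay: 4-methylphenyl gives a 4.4-fold higher number from compound 3 to compound 4 (0.64 log units; beyond the scatter) and a 2.6-fold higher number from compound 2 to compound 4 (0.42 log units; beyond the scatter) and also a 2.6-fold higher number from compound 1 to compound 4 (0.42 log units; beyond the scatter). Methyl in place of fluoro on an aromatic carbon is thus enough to move the number beyond the scatter, whereas 4-fluorophenyl in place of naphthalen-1-yl did not, so the size of a change in this group does not by itself tell how far the number moves. Nothing at hand gives a cause for this result.

The compounds shown leave open whether the higher number belongs to methyl specifically or would come with other groups on that aromatic carbon. Methoxy or dimethylamino there would help separate these two readings.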